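The source may report more compounds than this note shows. Statements on the series, on what has been measured and on what is new or still open speak of the compounds shown alone.

Measured compounds in a physicochemical assay for solubility, read by HPLC, in simulated intestinal fluid, with a stated time of 16 h, tested at 125 ug/mL; a higher number here means a more soluble compound, a lower number a less soluble compound:
compound 1, `CNC(=O)c1cc(C(=O)NC2CC2)cn(Cc2ccc(OC)cc2)c1=O`: 263 ug/mL
compound 2, `CNC(=O)c1cc(C(=O)NC2CC2)c(C)n(Cc2ccccc2)c1=O`: 577 ug/mL

Of these two numbers, compound 1 gives the lower one; compound 2 stands higher by a gap beyond the usual scatter. Among the measured compounds shown here, the two compounds differ in more than one place, so no single step between them is counted, and their values show only that much.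

Compound 3, `CNC(=O)c1cc(C(=O)NC2CC2)cn(Cc2cccc([C@@H](C)O)c2)c1=O`, has not yet been measured in this assay. It differs from compound 1 as follows: 3-(1-hydroxyethyl)phenyl in place of 4-methoxyphenyl on a saturated chain carbon bound to an aromatic nitrogen. For the measured compounds named here, no measured step covers this exact change, so the expectation rests on the two numbers alone. The expected step from compound 1 to compound 3 in this assay is a 1.5-fold higher number from compound 1 to compound 3 (0.18 log units; within the scatter), a modest rise, though a result within the scatter would not be surprising. Compound 3 is therefore estimated at 400 ug/mL, with a likely range from 200 ug/mL to 800 ug/mL.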

Compound 3, solubility: 495 ug/mL
Compound 3: middle estimate off by 1.2-fold (0.09 log units), on the low side, within the range that was stated.
By their numbers in this assay, from the lowest: compounds 1, 3 and 2 (each within the scatter of the next, the first and the last beyond it).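

In this assay, the place on a saturated chain carbon bound to an aromatic nitrogen takes 3-(1-hydroxyethyl)phenyl in place of 4-methoxyphenyl with a 1.9-fold higher number from compound 1 to compound 3 (0.27 log units; within the scatter) as the printed step. Among the compounds shown here, this is the first comparison here in which only one place differs, and the step stays within the usual scatter, even though the entering group carries a hydrogen-bond donor and a defined stereocentre. Nothing available explains the size of this step.

The compounds shown leave open what a different kind of group at this place, such as an amine or a carboxylic acid on the phenyl ring, would give. They also leave open how the other stereoisomer of the 1-hydroxyethyl group would compare with compound 3.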